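Methyl for Amino on the Core of Compound 1

A few compounds are considered here, and "the series" means these few. Any claim that something is new, unique, unknown or untested is made for them only; others in the source may bear on it.

Three compounds have numbers so far:
compound 1 `Nc1ccc2c(c1)OCCCN2S(=O)(=O)c1ccc(-c2cnc(C3CC3)o2)cc1` with 33 nM;
compound 2 `COc1ccc2c(c1)N(S(=O)(=O)c1ccc(-c3cnc(C4CC4)o3)cc1)CCCO2` with 14 nM;
compound 3 `O=S1(=O)CCCN(S(=O)(=O)c2ccc(-c3cnc(C4CC4)o3)cc2)c2ccccc21` with 5880 nM.

In a functional assay on PC-3 cells (Homo sapiens) for antiproliferative activity, read by MTT assay, with a stated time of 72 h (on this read-out higher numbers stand for weaker inhibition and lower numbers for stronger inhibition), compound 1 gives 33 nM, the second highest of the three numbers. Compound 2 gives 14 nM, a lower number by a gap beyond the scatter, while compound 3 gives 5880 nM, a far higher number.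

Compound 4 `Cc1ccc2c(c1)OCCCN2S(=O)(=O)c1ccc(-c2cnc(C3CC3)o2)cc1` has not been measured. It differs from compound 1 by methyl in place of amino on an aromatic carbon, a methyl in place of amino on an aromatic carbon of the shared core. No such swap between measured compounds is on hand, so a small step is expected, probably toward a lower number, given that compound 2 with its methoxy gives 14 nM. The estimate for compound 4 is 25 nM, within 8 nM to 80 nM, a step of a 1.3-fold lower number from compound 1 to compound 4 (0.12 log units; within the scatter).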

Compound 4, half-maximal inhibitory concentration: 241 nM
Beside the measured number, compound 4's estimate is 9.6-fold (0.98 log units) below it; the whole stated range lies below it.
By their numbers in this assay, from the lowest: compound 2; then compound 1; then compound 4; then compound 3.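

In this assay methyl in place of amino on an aromatic carbon of the shared core gives a 7.3-fold higher number from compound 1 to compound 4 (0.86 log units; beyond the scatter) and so shows that this position is sensitive even to a swap of one heavy atom for another. The earlier compounds shown here offered no single-place step to show this. The swap removes the hydrogen-bond donor and acceptor counted for amino, but no measurement here links the step to them or gives any other cause. Going by these compounds, whether a hydroxyl or a chlorine here would stay near compound 1 or move toward compound 4 remains open.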